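Swapping the aryl on the nitrogen of a glucagon receptor series

A few compounds are considered here, and "the series" means these few. Any claim that something is new, unique, unknown or untested is made for them only; others in the source may bear on it.

Compound 1 `Cc1cc(N(Cc2ccc(C(=O)NCCC(=O)O)cc2)c2nc(-c3ccc(C(F)(F)F)cc3)cs2)ccc1C(C)C` is measured in an in vitro assay on BHK cells for displacement of a labelled ligand from Glucagon receptor (Homo sapiens), read by scintillation proximity assay (on this read-out higher numbers stand for weaker inhibition and lower numbers for stronger inhibition), where compound 1 gives 119 nM. Compound 2 `O=C(O)CCNC(=O)c1ccc(CC(c2ccc(Cl)cc2)c2nc(-c3ccc(C(F)(F)F)cc3)cs2)cc1` gives 96 nM and compound 3 `O=C(O)CCNC(=O)c1ccc(CC(c2ccc(Cl)cc2)c2nc(-c3ccc(OC(F)(F)F)cc3)cs2)cc1` gives 153 nM; compound 1 therefore sits second highest of the three, yet all three lie within the scatter of one another. Compound 4 `O=C(O)CCNC(=O)c1ccc(CN(c2ccc(OC(F)(F)F)cc2)c2nc(-c3ccc(C(F)(F)F)cc3)cs2)cc1` differs from compound 1 in one place: 4-(trifluoromethoxy)phenyl in place of 4-isopropyl-3-methylphenyl on a nitrogen on an aromatic ring. Among the measured compounds shown here, the only measured step, a 1.6-fold higher number from compound 2 to compound 3 (0.20 log units; within the scatter), concerns a different aryl group and stays within the scatter, so no measured step speaks directly to this change. The step from compound 1 to compound 4 is expected to be a 1.3-fold higher number from compound 1 to compound 4 (0.10 log units; within the scatter), likely not beyond the scatter. Compound 4 is estimated at 150 nM, ranging from 60 nM to 400 nM.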

Compound 4, half-maximal inhibitory concentration: 92 nM
For compound 4 the middle estimate is 1.6-fold (0.21 log units) above the measured one; measured number inside the range.
By their numbers in this assay, from the lowest: compounds 4, 2, 1 and 3 (each within the scatter of the next).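

On the nitrogen on an aromatic ring, 4-(trifluoromethoxy)phenyl in place of 4-isopropyl-3-methylphenyl gives a 1.3-fold lower number from compound 1 to compound 4 (0.11 log units; within the scatter) in this assay. This position therefore takes an aryl with oxygen and fluorine as well as one with carbon alone, with no change beyond the scatter. No evidence bears on why the two aryl groups read alike. The compounds shown leave open whether an unsubstituted phenyl, a pyridyl or a saturated cyclohexyl on this nitrogen would hold the reading.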